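Returning to a bicyclic group on the ether chain

The source may report more compounds than this note shows. Statements on the series, on what has been measured and on what is new or still open speak of the compounds shown alone.

Measured compounds:
compound 1, `COc1ccc(CN(C(=O)Cn2cc(COc3ccc4ccc(=O)oc4c3)nn2)c2cc(OC)c(OC)c(OC)c2)cc1`, 1300 nM
compound 2, `COc1ccc(CN(C(=O)Cn2cc(COc3ccc4c(C)cc(=O)oc4c3)nn2)c2cc(OC)c(OC)c(OC)c2)cc1`, 1740 nM
compound 3, `COc1ccc(CN(C(=O)Cn2cc(COc3ccccc3)nn2)c2cc(OC)c(OC)c(OC)c2)cc1`, 20500 nM

In a functional assay on HepG2 cells (Homo sapiens) for antiproliferative activity, read by MTT assay, with a stated time of 48 h (on this read-out higher numbers stand for weaker inhibition and lower numbers for stronger inhibition), compound 3 stands at the highest number of the three, above compound 2 by a 12-fold higher number from compound 2 to compound 3 (1.07 log units; beyond the scatter) and above compound 1 by a 16-fold higher number from compound 1 to compound 3 (1.20 log units; beyond the scatter), both beyond the scatter; compound 1 and compound 2 sit within the scatter of each other, a 1.3-fold higher number from compound 1 to compound 2 (0.13 log units; within the scatter).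

Compound 4, `COc1ccc(CN(C(=O)Cn2cc(CSc3nc4ccccc4o3)nn2)c2cc(OC)c(OC)c(OC)c2)cc1`, differs from compound 3 by (1,3-benzoxazol-2-yl)sulfanyl in place of phenoxy on a saturated chain carbon bound to an aromatic carbon. Within the data shown here, the steps that bear on this are a 16-fold higher number from compound 1 to compound 3 (1.20 log units; beyond the scatter) and a 12-fold higher number from compound 2 to compound 3 (1.07 log units; beyond the scatter), where a single carbon ring on the oxygen in place of a fused two-ring group went with a large rise in the number. Compound 4 again carries a fused two-ring group on that chain carbon, though joined through sulfur and with a different ring, so a lower number than compound 3 is expected, of smaller and less certain size. The estimate for compound 4 in this assay is 2500 nM, between 700 nM and 9000 nM, a step of an 8.2-fold lower number from compound 3 to compound 4 (0.91 log units; beyond the scatter).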

Compound 4, half-maximal inhibitory concentration: 15600 nM
Beside the measured number, compound 4's estimate is 6.2-fold (0.80 log units) below it, outside the stated range (above it).
By their numbers in this assay, from the lowest: compounds 1 and 2 (each within the scatter of the next); then compounds 4 and 3 (each within the scatter of the next).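

In this assay, (1,3-benzoxazol-2-yl)sulfanyl in place of phenoxy on a saturated chain carbon bound to an aromatic carbon gives a 1.3-fold lower number from compound 3 to compound 4 (0.12 log units; within the scatter) and so leaves the read-out within the scatter. Among these compounds, a fused two-ring group at this place is therefore not enough on its own to reach the numbers of compound 1, as a 12-fold higher number from compound 1 to compound 4 (1.08 log units; beyond the scatter) shows, and the earlier comparisons could not reveal this. No measurement shown here explains the result.

The group of compound 4 differs from that of compound 1 in both its ring system and its linking atom, so the compounds shown do not tell which of the two matters. Going by these compounds, how (1,3-benzoxazol-2-yl)oxy or naphthalen-2-yloxy would read at this place remains open.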